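A few compounds are considered here, and "the series" means these few. Any claim that something is new, unique, unknown or untested is made for them only; others in the source may bear on it.

Compound 1 `Nc1ccc(CNC(=O)Nc2ccc(CN3C(=O)c4ccccc4C3=O)cc2)cn1`: 100 nM
Compound 2 `C[C@H](NC(=O)c1cccc(F)c1)c1ccc(NC(=O)N2CC(c3cccnc3)C2)cc1`: 2.3 nM

Both compounds were tested in a functional assay on A2780 cells (Homo sapiens) for antiproliferative activity, read by CellTiter-Glo, with a stated time of 72 h; a lower number here means a stronger inhibitor, a higher number a weaker inhibitor. Compound 2, at 2.3 nM, holds the lower of the two numbers, and its gap from compound 1, at 100 nM, lies beyond the usual scatter. Compound 3 `CCC(=O)N[C@@H](C)c1ccc(NC(=O)N2CC(c3cccnc3)C2)cc1` has not yet been measured. It departs from compound 2 in one place: ethyl in place of 3-fluorophenyl on a carbonyl carbon. The ring is thus lost from that end of the molecule. For the measured compounds named here, no pair of measured compounds differs in one place only, so the data show nothing directly about this change. A weaker compound is still the more likely outcome, with a moderate rise in the number that probably exceeds the scatter. The expected change is a 5.2-fold higher number from compound 2 to compound 3 (0.72 log units; beyond the scatter). For compound 3 the estimated value is 12 nM, with an expected range from 3 nM to 50 nM.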

Compound 3, half-maximal inhibitory concentration: 25 nM
Compound 3: the middle estimate sits 2.1-fold (0.32 log units) below what was measured, and the stated range covers the measured number.
By their numbers in this assay, from the lowest: compound 2; then compound 3; then compound 1.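

For the compounds shown here, replacing the 3-fluorophenyl on the carbonyl carbon with ethyl gives an 11-fold higher number from compound 2 to compound 3 (1.04 log units; beyond the scatter) in this assay, so this position, about which the earlier compounds showed nothing directly, clearly responds to a single change. The ring is not needed for activity in this assay, however, as compound 3 still gives 25 nM without it. Nothing measured here accounts for the size of this step.

With this single pair, the loss of the ring cannot be separated from the loss of the fluorine, as the two groups differ in both. From the compounds shown here alone, it remains open whether an unsubstituted phenyl, a cyclopropyl or a longer chain such as butyl on the same carbonyl carbon would give a number nearer to that of compound 2 or of compound 3.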